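Methyl on the Outer Ring in Two Thiazolopyrimidine Pairs

The source may hold more compounds than are shown below. What is called first, only, known or untested is meant among the compounds shown, and "the series" means these compounds.

Compound 1 `Cc1nc2sc(Nc3ccccc3)nc2c(=O)[nH]1` carries a phenylamino group on its core. In an assay on CHO cells for displacement of a labelled ligand from adenosine receptor A1 (Homo sapiens), read by scintillation counting, with a stated time of 120 min, tested at 1 uM (on this read-out lower numbers stand for less inhibition and higher numbers for more inhibition at the one concentration tested (going by the name of the read-out)), compound 1 gives 24%. Compound 2 `Cc1cccc(Nc2nc3c(=O)[nH]c(C)nc3s2)c1` differs from it by one change, (methyl in place of hydrogen on an aromatic carbon), and in this assay compound 2 gives 12%. That step amounts to a number 12 percentage points lower from compound 1 to compound 2 (beyond the scatter).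

Compound 3 `CCOc1nc(C)nc2sc(-c3ccccc3)nc12` has a different core; the difference between the cores of compound 1 and compound 3 is not broken down here. In this assay compound 3 gives 11%, a value that lies within the scatter of compound 2 and beyond the scatter below compound 1.

Compound 4 `CCOc1nc(C)nc2sc(-c3ccc(C)cc3)nc12` is yet to be measured. It differs from compound 3 by methyl in place of hydrogen on an aromatic carbon. This is the same kind of change as that from compound 1 to compound 2, though there the methyl sits meta to a large group and here para to a large group, and the cores differ. Resting on the step from compound 1 to compound 2 a number 12 percentage points lower from compound 1 to compound 2 (beyond the scatter), a step of a number 3 percentage points lower from compound 3 to compound 4 (within the scatter) is expected, small because compound 3 already stands at 11%. Compound 4 is therefore estimated at 8%, between -2% and 20%.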

Compound 4, a percentage reported as inhibition, at one concentration (the size of the read-out at that concentration, not a potency): 1%
Compound 4: middle estimate off by 7 percentage points, on the high side; measured number inside the range.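

In this assay, the new step reads a number 10 percentage points lower from compound 3 to compound 4 (within the scatter). Set beside the earlier step, the same methyl change gives steps that cannot be told apart on the two cores: the same change on two cores in this assay, a number 12 percentage points lower (beyond the scatter) from compound 1 to compound 2 and a number 10 percentage points lower (within the scatter) from compound 3 to compound 4, 2 percentage points apart, within the scatter of two such steps. Among these compounds, this does not show that the change carries over in general: there are only two pairs, only the earlier step lies beyond the scatter, the methyl of compound 4 sits para to a large group while that of compound 2 does not, and each read-out comes from one concentration and is not a potency.

The compounds shown leave open how an outer ring bearing a chlorine atom, a methoxy group or an amine would read on either core, and whether a longer chain in place of the methyl would follow the same course. They also leave open how the methyl, para to a large group, would read on the core of compound 1.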